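A Larger Group Replaces Chloro in Compound 3

A few compounds are considered here, and "the series" means these few. Any claim that something is new, unique, unknown or untested is made for them only; others in the source may bear on it.

In a functional assay on A549 cells (Homo sapiens) for cytotoxicity, read by MTT assay, with a stated time of 68 h (on this read-out lower numbers stand for stronger inhibition and higher numbers for weaker inhibition), compound 1 `Cc1cccc(-c2cccc(NC(=O)C(Cl)Cl)c2)c1` gives 8700 nM, and compound 2 `O=C(Nc1cccc(-c2cccc(Cl)c2)c1)C(Cl)Cl` gives 21400 nM. For the measured compounds named here, compound 2 therefore holds the higher of the two numbers so far, which makes it the weaker of the pair. Compound 3 `O=C(Nc1cccc(-c2cccc(NC(=O)C(Cl)Cl)c2)c1)C(Cl)Cl` changes compound 2 at the chloro position: ((dichloromethyl)carbonyl)amino in place of chloro on an aromatic carbon. In words, ((dichloromethyl)carbonyl)amino takes the place of chloro, and that same group is already present in compounds 1 and 2. Going by the values given here, the one measured step that bears on this change is a 2.5-fold higher number from compound 1 to compound 2 (0.39 log units; beyond the scatter), a modest move in which chloro replaced methyl. Among the compounds with values here, it is only a loose guide, and no measured step shows what a group of this size does here. A modest step towards a lower number is expected, estimated as a 2.1-fold lower number from compound 2 to compound 3 (0.33 log units; beyond the scatter). For compound 3 the estimated value is 10000 nM, with an expected range from 3000 nM to 30000 nM.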

Compound 3, half-maximal inhibitory concentration: 47900 nM
Estimate against measurement, compound 3: 4.8-fold (0.68 log units) below; the measured number lies above the stated range.
By their numbers in this assay, from the lowest: compound 1; then compound 2; then compound 3.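

In this assay, putting ((dichloromethyl)carbonyl)amino at this position gives a 2.2-fold higher number from compound 2 to compound 3 (0.35 log units; beyond the scatter) and so continues the upward direction seen when chloro replaced methyl, rather than reversing it. Against methyl the gap widens to a 5.5-fold higher number from compound 1 to compound 3 (0.74 log units; beyond the scatter) and, of the three groups tested at this position, methyl keeps the lowest number and thus the strongest inhibition of cell growth. Nothing available explains why the numbers rise in this order.

The compounds shown leave open whether the rise comes from the amide part of the new group or from its dichloromethyl end, which a plain acetylamino group at the same place could help to separate. They also leave open how an amine, a hydroxyl or a carboxylic acid would read there.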